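The source may hold more compounds than are shown below. What is called first, only, known or untested is meant among the compounds shown, and "the series" means these compounds.

Measured in a functional assay on K562 cells (Homo sapiens) for cytotoxicity, read by trypan blue exclusion, with a stated time of 96 h (a higher number here means a weaker inhibitor, a lower number a stronger inhibitor), so far
compound 1 `COc1cc(OC)c(/C=C/S(=O)(=O)Nc2ccc(OC)c(OP(=O)(O)O)c2)c(OC)c1` gives 7.5 nM 
compound 2 `COC(=O)C(C)Nc1cc(NS(=O)(=O)/C=C/c2c(OC)cc(OC)cc2OC)ccc1OC` gives 300 nM 
compound 3 `COC(=O)C(C)(C)Nc1cc(NS(=O)(=O)/C=C/c2c(OC)cc(OC)cc2OC)ccc1OC` gives 300 nM 

Compound 3 at 300 nM stands level with compound 2 and shares the highest number of the three, well above compound 1. Next is compound 4 `COC(=O)C(Nc1cc(NS(=O)(=O)/C=C/c2c(OC)cc(OC)cc2OC)ccc1OC)c1ccccc1` with this change: methoxycarbonyl)(benzyl in place of 1-(methoxycarbonyl)-1-methylethyl on a nitrogen on an aromatic ring in words methoxycarbonyl)(benzyl in place of 1-(methoxycarbonyl)-1-methylethyl on a nitrogen on an aromatic ring. The nearest evidence is no change at the digits printed from compound 2 to compound 3 (within the scatter) for methyl in place of hydrogen on a saturated chain carbon. The steps of a 40-fold higher number from compound 1 to compound 2 (1.60 log units; beyond the scatter) and a 40-fold higher number from compound 1 to compound 3 (1.60 log units; beyond the scatter) are large but concern a different swap, on an aromatic carbon. For the measured compounds named here, no measured step brings in an aromatic ring here. A step of a 1.2-fold higher number from compound 3 to compound 4 (0.07 log units; within the scatter) is expected in this assay and so nothing beyond the scatter. For compound 4 the estimate is 350 nM with an expected range from 100 nM to 1200 nM in this series.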

Compound 4, half-maximal inhibitory concentration: 2500 nM
Compound 4: the middle estimate sits 7.1-fold (0.85 log units) below what was measured, and the stated range ends below it.
By their numbers in this assay, from the lowest: compound 1; then compounds 2 and 3 (each within the scatter of the next); then compound 4.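

In this assay, the saturated chain carbon bound to the carbonyl carbon and the nitrogen shows a clear response to phenyl in place of methyl, an 8.3-fold higher number from compound 2 to compound 4 (0.92 log units; beyond the scatter), whereas an added methyl gave no change at the digits printed from compound 2 to compound 3 (within the scatter). Methoxycarbonyl)(benzyl in place of 1-(methoxycarbonyl)-1-methylethyl gives an 8.3-fold higher number from compound 3 to compound 4 (0.92 log units; beyond the scatter), and the gap to the parent widens to a 330-fold higher number from compound 1 to compound 4 (2.52 log units; beyond the scatter). No measurement at hand accounts for this rise.

Going by these compounds, it remains open whether a cyclohexyl group or a longer chain on that carbon would match phenyl. On these data alone, the effect of a carboxylic acid in place of the methyl ester also remains open.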